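Trading a Ring for a Methyl on a Lactam Scaffold

This account rests on a few compounds, and the source may have more. Where it says the series, first, only, none or still open, it means among the compounds named here.

Compound 2 `Cc1cc(C)c(CN2CCc3c(Cl)cc([C@H](CO)[C@@H]4CCCO4)c(Cl)c3C2=O)c(=O)[nH]1` was tested in an assay on cells for inhibition of histone-lysine N-methyltransferase EZH2 (Homo sapiens), read by ELISA, with a stated time of 72 h (a lower number here means a stronger inhibitor, a higher number a weaker inhibitor), and gave 41 nM. That is the only number shown for compound 2; a second entry for it in this assay carries no single number. Compound 1 `COC(c1cc(Cl)c2c(c1Cl)C(=O)N(Cc1c(C)cc(C)[nH]c1=O)CC2)C1CCS(=O)(=O)CC1` is the other measured compound; in this assay compound 1 gives 430 nM; 18 nM (2 entries), two entries that sit far apart, as the several entries of compound 1 in this assay, 430 nM; 18 nM (2 entries) shows. Among the compounds with values here, no step between two measured compounds is available, so compound 2 is the sole anchor for what follows.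

Compound 3 `Cc1cc(C)c(CN2CCc3c(Cl)cc([C@@H](C)CO)c(Cl)c3C2=O)c(=O)[nH]1` differs from compound 2 in one place: methyl in place of oxolan-2-yl on a saturated chain carbon bound to an aromatic carbon and a saturated chain carbon. The five-membered ring with its single hydrogen-bond acceptor leaves, and a methyl takes its place on the same saturated chain carbon. Within the data shown here, with no measured step to lean on, the expected step is a moderate weakening, larger than the usual scatter: a 3.7-fold higher number from compound 2 to compound 3 (0.56 log units; beyond the scatter). Compound 3 is therefore expected to give about 150 nM in this assay, with a range from 40 nM to 600 nM.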

Compound 3, half-maximal inhibitory concentration in the histone-lysine N-methyltransferase EZH2 assay: 1040 nM
The estimate for compound 3 lay 6.9-fold (0.84 log units) below the measured number; measured number above the stated range.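

In the histone-lysine N-methyltransferase EZH2 assay compound 2 gives 41 nM and compound 3 gives 1040 nM. In the histone-lysine N-methyltransferase EZH2 assay the swap gives a 25-fold higher number from compound 2 to compound 3 (1.40 log units; beyond the scatter), so the group on this saturated chain carbon has a strong hold on the number. In a physicochemical assay for lipophilicity, at pH 7.4 (a higher number here means a more lipophilic compound, a lower number a more polar compound), compound 2 gives 2.4 and compound 3 gives 2.5. In the physicochemical assay the same swap gives a number 0.10 log units higher from compound 2 to compound 3 (within the scatter), so the two compounds cannot be told apart on this read-out even though they lie far apart on inhibition. The change is thus a case where a large step in the histone-lysine N-methyltransferase EZH2 assay comes with no step beyond the scatter in the distribution coefficient.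

Because the whole oxolan-2-yl group leaves, with its ring, its oxygen and its defined stereocentre, this single step cannot say which of these carries the difference; a cyclopentyl group, with carbon in place of the ring oxygen, or an open chain such as methoxymethyl at the same carbon would pull those features apart. How closely a single number in the histone-lysine N-methyltransferase EZH2 assay can be read also stays open, since entries for one compound can sit far apart: the several entries of compound 1 in the histone-lysine N-methyltransferase EZH2 assay, 430 nM; 18 nM (2 entries)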